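The source may report more compounds than this note shows. Statements on the series, on what has been measured and on what is new or still open speak of the compounds shown alone.

Measured so far:
Compound 1, `CN(C)C(=O)c1cc2cnc(Nc3ccc(C(=O)NCCCN=C=S)cc3)nc2n1C1CCCC1`: 91.2%
Compound 2, `CN(C)C(=O)c1cc2cnc(Nc3ccc(C(=O)NCCCCCCCN=C=S)cc3)nc2n1C1CCCC1`: 107%

Both compounds were tested in a functional assay on NCI-H1299 cells (Homo sapiens) for inhibition, read by CCK-8 assay, with a stated time of 72 h, tested at 10 uM; on this read-out higher numbers stand for a stronger effect at the one concentration tested and lower numbers for a weaker effect. Compound 1 stands lowest of the two numbers; its nearest neighbour is compound 2, and the step of a number 15.8 percentage points higher from compound 1 to compound 2 (beyond the scatter) accompanied a longer saturated chain ending in the isothiocyanate group. Compound 3, `CN(C)C(=O)c1cc2cnc(Nc3ccc(NC(=O)CCCCCN=C=S)cc3)nc2n1C1CCCC1`, has not yet been measured. It differs from compound 1 by a group of 11 heavy atoms (7 carbon, 2 nitrogen, 1 oxygen, 1 sulfur; no ring) in place of a group of 9 heavy atoms (5 carbon, 2 nitrogen, 1 oxygen, 1 sulfur; no ring), on an aromatic carbon. For the measured compounds named here, the entering group is larger than the one that leaves, so the side chain on the aromatic ring again grows, but the entering group is not simply the leaving group with a longer chain, and no measured pair covers that part of the change. Going by the values given here, only the step from compound 1 to compound 2 bears on it; it was modest and ran towards stronger inhibition. A step of similar or somewhat smaller size in the same direction is therefore expected, a number 7.8 percentage points higher from compound 1 to compound 3 (within the scatter), with the read-out already close to full inhibition. Compound 3 is estimated at 99%, within a range from 86% to 110%.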

Compound 3, a percentage reported as inhibition, at one concentration (the size of the read-out at that concentration, not a potency): 85%
Beside the measured number, compound 3's estimate is 14 percentage points above it; measured number outside the range, below it.
By their numbers in this assay, from the lowest: compounds 3 and 1 (each within the scatter of the next); then compound 2.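

In this assay, exchanging the side chain of compound 1 for the larger one in compound 3, on the same aromatic carbon para to a large group, gave a number 6.2 percentage points lower from compound 1 to compound 3 (within the scatter), so the two compounds cannot be told apart on this read-out. For the compounds shown here, the earlier step, a number 15.8 percentage points higher from compound 1 to compound 2 (beyond the scatter), was the only change at this position known until now and had gone beyond the scatter, whereas this second enlargement of the side chain, in which the amide linking the chain is also turned round, does not repeat it, so a larger group here does not by itself go with a higher number. Nothing available explains this difference between the two changes, and the data cannot separate the effect of the chain length from that of the turned amide.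

From the compounds shown here alone, all three compounds end in an isothiocyanate, so how much of the inhibition depends on that end group remains open, and a chain ending in an amine would test this. A longer chain on the turned amide would show whether chain length matters there as well, which would allow a cleaner comparison with compound 2.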